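The source may hold more compounds than are shown below. What is called first, only, known or untested is meant among the compounds shown, and "the series" means these compounds.

Measured compounds:
compound 1, `CO[C@H]1CC[C@@H](CNc2cc(NCc3cnccc3C(F)(F)F)ncc2C#N)CC1` — 70 nM
compound 2, `CC1(C)C[C@H](Nc2nc(NCc3cnccc3C(F)(F)F)ncc2C#N)CC[C@@H]1O` — 6 nM

Both numbers come from an assay on isolated protein for inhibition of protein kinase C theta type (Homo sapiens), read by TR-FRET, with a stated time of 2 h; on this read-out lower numbers stand for stronger inhibition and higher numbers for weaker inhibition. Compound 1 gives the higher of the two values; compound 2 sits well below it, and the gap between them lies beyond the usual scatter. The two compounds differ in more than one place, so that gap cannot be broken down into single steps; it only shows that the series reaches lower numbers than compound 1 does.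

Compound 3, `CC1(C)[C@H](Nc2cc(NCc3cnccc3C(F)(F)F)ncc2C#N)C[C@H]1C(N)=O`, has not yet been measured in this assay. It derives from compound 1 by a single change: 3-carbamoyl-2,2-dimethylcyclobutyl in place of (4-methoxycyclohexyl)methyl on a nitrogen on an aromatic ring. A six-membered ring gives way to a four-membered one carrying two methyl groups and a carbamoyl group in place of a methoxy group.

Among the measured compounds shown here, no measured step between compounds differing in one place is available, so the size of this step has no precedent. The expectation is a modest move toward a lower number in this assay, about the size of the scatter, giving an expected step of a 1.8-fold lower number from compound 1 to compound 3 (0.24 log units; within the scatter). Compound 3 is accordingly estimated at 40 nM, with a range from 10 nM to 200 nM.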

Compound 3, half-maximal inhibitory concentration: 140 nM
For compound 3 the middle estimate is 3.5-fold (0.54 log units) below the measured one, within the range that was stated.
By their numbers in this assay, from the lowest: compound 2; then compounds 1 and 3 (each within the scatter of the next).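

In this assay, among the compounds shown here, 3-carbamoyl-2,2-dimethylcyclobutyl in place of (4-methoxycyclohexyl)methyl on a nitrogen on an aromatic ring gives a 2.0-fold higher number from compound 1 to compound 3 (0.30 log units; within the scatter), the first step that can be read at a single place. At this position, then, a six-membered non-aromatic ring of carbon only can give way to a four-membered one, and a methoxy group to a carbamoyl group that brings a hydrogen-bond donor, with no shift beyond the scatter at an equal count of heavy atoms in the two groups. Nothing at hand accounts for this result.

For the compounds shown here, the smaller ring, the two methyl groups and the carbamoyl group all enter together in this one step, so their separate contributions remain unresolved, and the single pair gives no general rule for this position. Also open, from the compounds shown here alone, is how the reading in this assay would respond to a carboxylic acid or an amine in place of the carbamoyl group on the 2,2-dimethylcyclobutyl ring.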